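A chloro group on compound 2 in a cytotoxicity test

This account rests on a few compounds, and the source may have more. Where it says the series, first, only, none or still open, it means among the compounds named here.

In an ADME assay on Huh-7 cells (Homo sapiens) for cytotoxicity, read by a luciferase reporter and WST assay, with a stated time of 3 days (on this read-out lower numbers stand for higher toxicity in this test and higher numbers for lower toxicity in this test), two compounds have been read so far. Compound 1 (`O=C(Nc1ccccc1)c1c(NO)cc(-c2ccc(Cl)cc2)oc1=O`) gives 11000 nM as its half-maximal cytotoxic concentration. Compound 2 (`CNC(=O)c1c(NO)cc(-c2ccccc2)oc1=O`) has no number there, only the limit > 20000 nM as its reading.

Compound 3 (`CNC(=O)c1c(NO)cc(-c2ccc(Cl)cc2)oc1=O`) differs from compound 2 by a single change (chloro in place of hydrogen on an aromatic carbon), chloro in place of hydrogen on an aromatic carbon, para to a large group. For the measured compounds named here, no measured step between two compounds gives the size of such a change, so the expectation rests on little. Going by the values given here, the one guide is compound 1, whose 11000 nM shows that a number can be obtained in this assay with this kind of compound. What is expected is a small move toward higher toxicity in this test, an at least 1.2-fold lower number from compound 2 to compound 3 (0.09 log units; that floor lies within the scatter), possibly none beyond the scatter. For compound 3 the half-maximal cytotoxic concentration is estimated at 16000 nM with a range from 8000 nM to 30000 nM on repeated measurement, and the reading may again turn out to be only a limit.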

Compound 3, half-maximal cytotoxic concentration: > 20000 nM
Compound 3: a limit, no number; the forecaster's own chance of this, stated with the estimate: 50%; middle value at least 1.2-fold (0.09 log units) from the limit.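

Compound 3 carries the chloro group and still reads only as a limit, > 20000 nM in this assay as its reading, so chloro in place of hydrogen on this aromatic carbon, para to a large group, brings no number to a compound with methyl on the amide-type nitrogen. On these data alone, the pair that shares the chloro group does give a readable result, since methyl in place of phenyl on an amide-type nitrogen produces an at least 1.8-fold higher number from compound 1 to compound 3 (0.25 log units; that floor lies within the scatter) as its step, and that size is only a floor, so the true distance between the two stays unknown. The step for the chloro change itself cannot be read, because compound 2 and compound 3 both stop at the same limit: the limit of > 20000 nM in this assay, at which 2 of the 3 values shown sit.

As far as these compounds go, whether chloro at this position shifts the reading at all stays open, as does how any other group there, such as an amine or a carboxylic acid, would read in this assay on this core. Also open, from the compounds shown here alone, is where a longer chain such as ethyl on the amide-type nitrogen would fall relative to methyl and phenyl.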